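The source may hold more compounds than are shown below. What is called first, only, known or untested is meant among the compounds shown, and "the series" means these compounds.

Working notes on the series. Going by the values given here, compound 2 `c1cnc2c(c1)CCC[C@@H]2N(CCCN1CCNCC1)Cc1cc2ccccc2cn1` stands as the lowest of the two numbers so far in a functional assay on CCRF-CEM cells for antagonist activity at C-X-C chemokine receptor type 4 (Homo sapiens), read by calcium flux, with stated times of 25 min and 90 s (a higher number here means a weaker inhibitor, a lower number a stronger inhibitor), where compound 2 gives 17 nM; its nearest neighbour is compound 1 `c1ccc2c(c1)CN[C@H](CN(CCCN1CCNCC1)[C@H]1CCCc3cccnc31)C2`, which in this assay gives 1150 nM. Among the compounds with values here, the single measured step is a 68-fold lower number from compound 1 to compound 2 (1.83 log units; beyond the scatter), a large change on the saturated chain carbon bound to an amine nitrogen.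

Compound 3 `c1cnc2c(c1)CN[C@@H](CN(CCCN1CCNCC1)[C@H]1CCCc3cccnc31)C2` is not yet measured. It differs from compound 2 by a group of 10 heavy atoms (8 carbon, 2 nitrogen; one six-membered non-aromatic ring with 1 hetero atom, one six-membered aromatic ring with 1 hetero atom) in place of a group of 10 heavy atoms (9 carbon, 1 nitrogen; one six-membered aromatic ring of carbon only, one six-membered aromatic ring with 1 hetero atom), on a saturated chain carbon bound to an amine nitrogen, again on the saturated chain carbon bound to an amine nitrogen. The change bears directly on the measured step: the group that enters carries one six-membered non-aromatic ring with 1 hetero atom and one hydrogen-bond donor, as did the group in compound 1, and the group that leaves is the isoquinolin-3-yl that was gained from compound 1 to compound 2. The measured step of a 68-fold lower number from compound 1 to compound 2 (1.83 log units; beyond the scatter) is therefore expected to be reversed, with a change of comparable size. The expected step is a 41-fold higher number from compound 2 to compound 3 (1.61 log units; beyond the scatter). On that basis compound 3 is estimated at 700 nM in this assay, with a range from 200 nM to 2500 nM.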

Compound 3, half-maximal inhibitory concentration: 171 nM
Estimate against measurement, compound 3: 4.1-fold (0.61 log units) above; the measured number lies below the stated range.
By their numbers in this assay, from the lowest: compound 2; then compound 3; then compound 1.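

In this assay, the saturated chain carbon bound to an amine nitrogen now carries three groups of equal heavy-atom count, which allows the two ring differences to be read apart: with the six-membered non-aromatic ring with 1 hetero atom kept, a six-membered aromatic ring with 1 hetero atom in place of one of carbon only gives a 6.7-fold lower number from compound 1 to compound 3 (0.83 log units; beyond the scatter), while the isoquinolin-3-yl keeps its advantage, with a 10-fold higher number from compound 2 to compound 3 (1.00 log units; beyond the scatter). The group in compound 3 carries a hydrogen-bond donor and a non-aromatic ring, as the group in compound 1 does, yet its number lies between the other two, so neither feature fixes the number at the level of compound 1. No measurement shown here explains either step.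

The compounds shown leave open how a naphthalen-2-yl group, with both aromatic rings of carbon only, would read at this place, which would test the ring nitrogen of the isoquinolin-3-yl. Also open, as far as these compounds go, is whether a methyl group on the amine nitrogen of the non-aromatic ring in compound 3 would move the number towards that of compound 2.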